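This account rests on a few compounds, and the source may have more. Where it says the series, first, only, none or still open, it means among the compounds named here.

Three compounds have been measured in a functional assay on HepG2 cells (Homo sapiens) for antiproliferative activity, read by MTT assay; a lower number here means a stronger inhibitor, a higher number a weaker inhibitor:

compound 1 `O=C1N=C(N2CCC[C@H]2C(=O)Nc2ccc3ncnc(Nc4cccc(Cl)c4)c3c2)S/C1=C/c1cccc(Cl)c1`, which in this assay gives 27600 nM
compound 2 `O=C1N=C(N2CCC[C@H]2C(=O)Nc2ccc3ncnc(Nc4cccc(Cl)c4)c3c2)S/C1=C/c1ccccc1Br`, which in this assay gives 24300 nM
compound 3 `O=C1N=C(N2CCC[C@H]2C(=O)Nc2ccc3ncnc(Nc4cccc(Cl)c4)c3c2)S/C1=C/c1cccnc1Cl`, which in this assay gives 6400 nM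

Compound 1 stands at the highest number of the three, the weakest inhibitor among them. Its nearest neighbour is compound 2, with a 1.1-fold lower number from compound 1 to compound 2 (0.06 log units; within the scatter), while compound 3 lies furthest away, with a 4.3-fold lower number from compound 1 to compound 3 (0.63 log units; beyond the scatter); compound 2 and compound 3 are separated by a 3.8-fold lower number from compound 2 to compound 3 (0.58 log units; beyond the scatter).

The unmeasured compound 4 `O=C1N=C(N2CCC[C@H]2C(=O)Nc2ccc3ncnc(Nc4cccc(Cl)c4)c3c2)S/C1=C/c1ccccc1F` differs from compound 1 in one place: 2-fluorophenyl in place of 3-chlorophenyl on a double-bonded chain carbon bound to a double-bonded ring carbon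

Within the data shown here, the step that bears most closely on this change is the one from compound 1 to compound 2, where a different 2-halophenyl replaced the same 3-chlorophenyl and the number stayed within the scatter. The larger steps to compound 3 involve a pyridine ring, which compound 4 does not carry. The expectation is therefore no step beyond the scatter, with a 1.1-fold lower number from compound 1 to compound 4 (0.04 log units; within the scatter) as the expected change. For compound 4 the estimate in this assay is 25000 nM, expected to fall between 10000 nM and 60000 nM.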

Compound 4, half-maximal inhibitory concentration: 18200 nM
Compound 4: the middle estimate sits 1.4-fold (0.14 log units) above what was measured, and the stated range covers the measured number.
By their numbers in this assay, from the lowest: compound 3; then compounds 4, 2 and 1 (each within the scatter of the next).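

In this assay the swap to 2-fluorophenyl gives a 1.5-fold lower number from compound 1 to compound 4 (0.18 log units; within the scatter) and fluoro in place of bromo on an aromatic carbon gives a 1.3-fold lower number from compound 2 to compound 4 (0.13 log units; within the scatter) so compounds 1, 2 and 4 stay together within the scatter, whichever of the three halogens the phenyl ring carries and wherever it stands in these examples. Compound 3 still stands apart from this third halophenyl compound, with a 2.8-fold higher number from compound 3 to compound 4 (0.45 log units; beyond the scatter) and so far only its 2-chloropyridin-3-yl group has moved the number beyond the scatter at this position. No measurement here explains these results.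

A 2-chlorophenyl group and a pyridin-3-yl group without chlorine are not among these compounds, so the difference of compound 3 cannot yet be traced to a single atom. On these data alone, how a methoxy group or an amine on this ring would read also stays open.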